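A Tetrazole in Place of Methoxycarbonyl

The source may report more compounds than this note shows. Statements on the series, on what has been measured and on what is new or still open speak of the compounds shown alone.

In a functional assay (blood) for inhibition, with Homo sapiens as the target (a lower number here means a stronger inhibitor, a higher number a weaker inhibitor), compound 1 (`COC(C)c1cc(-c2ccccc2)c2ccc(OCc3cccc(C4(O)CCOCC4)c3)cc2c1`) reads > 1000 nM and this is a limit of the assay, not a number. Compound 2 (`CC(=O)c1cc(-c2ccccc2)c2ccc(OCc3cccc(C4(O)CCOCC4)c3)cc2c1`) gives 90 nM and compound 3 (`COC(=O)c1cc(-c2ccccc2)c2ccc(OCc3cccc(C4(O)CCOCC4)c3)cc2c1`) gives 100 nM in this assay as well. The two stand level, since the step (a 1.1-fold higher number from compound 2 to compound 3 (0.05 log units; within the scatter)) lies within the scatter.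

Compound 4 (`Cn1nnc(-c2cc(-c3ccccc3)c3ccc(OCc4cccc(C5(O)CCOCC5)c4)cc3c2)n1`) carries 2-methyl-2H-tetrazol-5-yl in place of methoxycarbonyl on an aromatic carbon. Two kinds of measured step bear on this change. Exchanging methyl for methoxy on the carbonyl carbon moved nothing beyond the scatter, as the step above shows. Leaving the carbonyl series cost far more, with a large step (an at least 11-fold lower number from compound 1 to compound 2 (1.04 log units; beyond the scatter)) and one of at least modest size (an at least 10-fold lower number from compound 1 to compound 3 (1.00 log units; beyond the scatter)). Compound 4 has no carbonyl either, so the risk lies towards a higher number, but its aromatic group differs from the 1-methoxyethyl of compound 1. The expected change (a 1.5-fold higher number from compound 3 to compound 4 (0.18 log units; within the scatter)) is no step beyond the scatter. Compound 4 is estimated at 150 nM with an expected range from 40 nM to 600 nM in this assay.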

Compound 4, half-maximal inhibitory concentration: 310 nM
Beside the measured number, compound 4's estimate is 2.1-fold (0.32 log units) below it, within the range that was stated.
By their numbers in this assay, from the lowest: compounds 2 and 3 (each within the scatter of the next); then compound 4. At a limit, above all of these: compound 1.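

In this assay the aromatic carbon of the shared core gives a clearly higher number with 2-methyl-2H-tetrazol-5-yl than with either carbonyl group: methoxycarbonyl (a 3.1-fold higher number from compound 3 to compound 4 (0.49 log units; beyond the scatter)) and acetyl (a 3.4-fold higher number from compound 2 to compound 4 (0.54 log units; beyond the scatter)). Even so, this group without a carbonyl still reads clear of 1-methoxyethyl (an at least 3.2-fold lower number from compound 1 to compound 4 (0.50 log units; beyond the scatter)), so a carbonyl is not the only group here that gives a lower number than compound 1. Going by these compounds, compound 1 stands at a limit of the assay, so this last step gives only a bound and its full size stays unknown: the limit of > 1000 nM in this assay, at which 1 of the 4 values shown sits.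

The compounds shown do not tell whether the rise belongs to the tetrazole ring or to its methyl group. An unmethylated tetrazole, a carboxylic acid or a primary amide at this position would bear on that question.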